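This account rests on a few compounds, and the source may have more. Where it says the series, first, only, none or still open, it means among the compounds named here.

Measured so far:
compound 1 `CO[C@@H]1CC=C2NN(c3cc(Cl)cc(Cl)c3)C(=O)C[C@]2(c2ccncc2)O1`, giving 5500 nM
compound 2 `COc1cc(OC)cc(N2NC3=CC[C@@H](OC)O[C@@]3(c3ccccc3)CC2=O)c1`, giving 1200 nM
compound 3 `CO[C@@H]1CC=C2NN(c3ccc(Cl)cc3)C(=O)C[C@]2(C)O1`, giving 28700 nM

These three compounds were tested in a functional assay on SK-BR-3 cells (Homo sapiens) for inhibition, read by sulforhodamine B assay, with a stated time of 48 h; a higher number here means a weaker inhibitor, a lower number a stronger inhibitor. Compound 3 gives the highest number of the three and is the weakest inhibitor here: compound 1 gives 5500 nM and compound 2 gives 1200 nM, and both gaps lie beyond the usual scatter. Compound 4 `CO[C@@H]1CC=C2NN(c3cccnc3)C(=O)C[C@]2(C)O1` has not been measured yet. It differs from compound 3 in one place: pyridin-3-yl in place of 4-chlorophenyl on an amide-type nitrogen in a ring. Among the measured compounds shown here, no pair of measured compounds differs by this change alone, so no measured step shows what it does. The expectation is a modest step toward a higher number, a 1.4-fold higher number from compound 3 to compound 4 (0.14 log units; within the scatter), though the step may well stay within the scatter. Compound 4 is therefore estimated at 40000 nM, in the range 12000 nM to 120000 nM.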

Compound 4, half-maximal inhibitory concentration: 15200 nM
The estimate for compound 4 lay 2.6-fold (0.42 log units) above the measured number; measured number inside the range.
By their numbers in this assay, from the lowest: compound 2; then compound 1; then compounds 4 and 3 (each within the scatter of the next).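

In this assay, among the compounds shown here, the first direct reading at this position shows that pyridin-3-yl in place of 4-chlorophenyl on the amide-type nitrogen in a ring gives a small step (a 1.9-fold lower number from compound 3 to compound 4 (0.28 log units; within the scatter)). Swapping the chlorine-bearing carbon ring for a ring with one ring nitrogen therefore leaves the number indistinguishable from that of compound 3. No measurement here explains this result.

On these data alone, whether a 4-aminophenyl or 4-carboxyphenyl group on that nitrogen would shift the number remains open. So does whether pyridin-3-yl would behave the same way where compound 1 and compound 2 carry a ring instead of the methyl group.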